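Notes on the step to compound 3

The compounds below may be only part of what the source reports. "The series", "measured", "known", "first", "only" and "open" are said of these compounds alone.

- compound 1 (`COc1cc(NC(=O)/C=C/c2cccc(OCc3ccccc3)c2)cc(OC)c1OC`): 3500 nM
- compound 2 (`C=C(Br)C(=O)Nc1cccc(/C=C/C(=O)Nc2ccccc2)c1`): 5000 nM

In a functional assay on Jurkat cells (Homo sapiens) for inhibition, read by MTT assay, with a stated time of 72 h (a lower number here means a stronger inhibitor, a higher number a weaker inhibitor), compound 2 gives 5000 nM against compound 1 at 3500 nM and the two values lie within the scatter of each other. Compound 3 (`C=C(Br)C(=O)Nc1cccc(/C=C/C(=O)Nc2ccc(F)c(F)c2)c1`) keeps the rest of compound 2 and differs by one change (3,4-difluorophenyl in place of phenyl on an amide-type nitrogen), with 3,4-difluorophenyl in place of phenyl on an amide-type nitrogen. Among the measured compounds shown here, no measured pair of compounds shows this change, and the two measured compounds differ in more than one place. Only a small step towards a lower number is expected in this assay and it may stay within the scatter. The expected step is a 1.7-fold lower number from compound 2 to compound 3 (0.22 log units; within the scatter) and it rests on the structural change alone. Compound 3 is estimated at 3000 nM (expected range 1000 nM to 8000 nM).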

Compound 3, half-maximal inhibitory concentration: 550 nM
Compound 3: middle estimate off by 5.5-fold (0.74 log units), on the high side; the whole stated range lies above it.
By their numbers in this assay, from the lowest: compound 3; then compounds 1 and 2 (each within the scatter of the next).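

In this assay, 3,4-difluorophenyl in place of phenyl on an amide-type nitrogen gives a 9.1-fold lower number from compound 2 to compound 3 (0.96 log units; beyond the scatter), so the group on this nitrogen can move the number beyond the scatter. Among the compounds shown here, this is the first comparison that differs in one place; compound 1 and compound 2 differ in more than one place and lie within the scatter of each other, so they could not show this. No available measurement accounts for the size of the step.

A single pair leaves open whether 3-fluorophenyl or 4-fluorophenyl alone would give a similar step, and whether 3,4-dichlorophenyl would follow it. It also leaves open whether the step would persist if hydrogen replaced the bromine of compound 3.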